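The compounds below may be only part of what the source reports. "The series", "measured", "known", "first", "only" and "open" are said of these compounds alone.

Three compounds have been measured in an assay on CHO cells for displacement of a labelled ligand from adenosine receptor A3 (Homo sapiens), read by scintillation counting, with a stated time of 3 h; a higher number here means a weaker inhibitor, a lower number a stronger inhibitor:
Compound 1, `Cn1c(-c2ccc(C(=O)O)cc2)nc2c(NC3CCCC3)ncnc21`, gives 25700 nM.
Compound 2, `Cn1c(-c2ccccc2Cl)nc2c(NC3CCCC3)ncnc21`, gives 720 nM.
Compound 3, `Cc1ccccc1-c1nc2c(NC3CCCC3)ncnc2n1C`, gives 3000 nM.

Compound 3 stands second highest of these three numbers, nearest to compound 2 and furthest from compound 1. Going by the values given here, the only single-change step measured so far is a 4.2-fold higher number from compound 2 to compound 3 (0.62 log units; beyond the scatter), a modest loss when methyl takes the place of chloro on the phenyl ring. Compound 4, `Cn1c(-c2ccc(Cl)cc2)nc2c(NC3CCCC3)ncnc21`, differs from compound 3 by 4-chlorophenyl in place of 2-methylphenyl on an aromatic carbon. Among the compounds with values here, the change brings chloro back, which in compound 2 went with the lower number, but the chloro of compound 4 sits differently on the phenyl ring than in compound 2, and no measured step covers that shift; compound 1, with another substituted phenyl, shows the highest number, but no single-change step links it to the rest. The expected step is therefore a 2.0-fold lower number from compound 3 to compound 4 (0.30 log units; within the scatter), a gain of uncertain size. Compound 4 is expected to give about 1500 nM, between 300 nM and 8000 nM.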

Compound 4, inhibition constant: 1210 nM
Estimate against measurement, compound 4: 1.2-fold (0.09 log units) above, and the stated range covers the measured number.
By their numbers in this assay, from the lowest: compounds 2 and 4 (each within the scatter of the next); then compound 3; then compound 1.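

In this assay, going by these compounds alone, 4-chlorophenyl in place of 2-chlorophenyl gives a 1.7-fold higher number from compound 2 to compound 4 (0.23 log units; within the scatter) and so cannot be told apart from it, which means this pair shows no clear effect of where the chloro sits on the phenyl ring. 4-Chlorophenyl in place of 2-methylphenyl gives a 2.5-fold lower number from compound 3 to compound 4 (0.39 log units; beyond the scatter) as a real but modest gain, while chloro in place of carboxy gives a 21-fold lower number from compound 1 to compound 4 (1.33 log units; beyond the scatter) as the largest step so far. Nothing available here explains why these groups differ.

As far as these compounds go, it remains open whether 4-methylphenyl would stand closer to 2-methylphenyl or to 4-chlorophenyl, which would separate the effect of the group from that of its place on the ring. From the compounds shown here alone, it also remains open how a plain phenyl, or an amine or a longer chain on the phenyl ring, would compare.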